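This account rests on a few compounds, and the source may have more. Where it says the series, first, only, none or still open, it means among the compounds named here.

Measured compounds:
- compound 1, `NCC[C@H]1CCO[C@@H](c2ccccc2)O1`: > 10000 nM
- compound 2, `CC[C@]1(c2ccccc2)OCC[C@H](CCNCc2ccccc2)O1`: 28 nM

In an assay on brain for displacement of a labelled ligand from Sigma non-opioid intracellular receptor 1 (Cavia porcellus) (a lower number here means a stronger inhibitor, a higher number a weaker inhibitor), compound 1 reaches only the assay limit, (the limit of > 10000 nM in this assay, at which 1 of the 2 values shown sits), not a number. Going by the values given here, compound 2 is the only compound with a numerical value in this assay; no step between measured compounds is available, and the pair of compounds 1 and 2 differs in more than one place.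

Compound 3, `c1ccc(CNCC[C@H]2CCO[C@@H](c3ccccc3)O2)cc1`, differs from compound 2 by hydrogen in place of ethyl on a saturated ring carbon. A moderate loss in this assay is expected, a 3.2-fold higher number from compound 2 to compound 3 (0.51 log units; beyond the scatter). For compound 3 the estimate in this assay is 90 nM, within 20 nM to 400 nM.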

Compound 3, inhibition constant: 50 nM
For compound 3 the middle estimate is 1.8-fold (0.26 log units) above the measured one, within the range that was stated.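

In this assay, hydrogen in place of ethyl on the saturated ring carbon between two ring oxygen atoms stays within the scatter: a 1.8-fold higher number from compound 2 to compound 3 (0.25 log units; within the scatter). Ethyl at this position is therefore not required for the affinity seen here, whereas benzyl in place of hydrogen on the amine nitrogen carries a large step: an at least 200-fold lower number from compound 1 to compound 3 (2.30 log units; beyond the scatter). Compound 1 gives a limit, not a number, so the full size of that step stays unknown: the limit of > 10000 nM in this assay, at which 1 of the 3 values shown sits.

Still open, as far as these compounds go, is how a longer chain or a hydroxyl at this ring carbon would read. Also open, from the compounds shown here alone, is whether phenethyl on the amine nitrogen would match benzyl.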